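The source may hold more compounds than are shown below. What is called first, only, known or untested is meant among the compounds shown, and "the series" means these compounds.

Measured so far:
compound 1, `CCOc1ccc2nc(C(F)(F)F)cc(OCC(=O)Nc3cc(C)cc(C)c3)c2c1`: 7.55
compound 2, `COc1ccc2nc(C)cc(OCC(=O)Nc3cc(F)cc(F)c3)c2c1`: 5.13

Both numbers come from a physicochemical assay for lipophilicity, read by HPLC, in phosphate buffer, measured as chromatographic lipophilicity, at pH 7.4; a lower number here means a more polar compound, a higher number a more lipophilic compound. Compound 2 gives the lower of the two values, and compound 1 stands higher by a gap that is clearly beyond the usual scatter of repeated measurements. Compound 3, `COc1ccc2nc(C)cc(OCC(=O)NNC(=O)c3ccncc3)c2c1`, has not yet been measured. It keeps the core of compound 2 and changes only the group on the amide-type nitrogen: ((pyridin-4-yl)carbonyl)amino in place of 3,5-difluorophenyl on an amide-type nitrogen. The leaving group carries no hydrogen-bond donors or acceptors, while the entering group brings one hydrogen-bond donor and two hydrogen-bond acceptors together with a ring that holds one hetero atom. Within the data shown here, no pair of measured compounds shows this kind of change, so the expectation rests on the change itself. A large downward step in this assay is expected, well beyond the scatter: a number 2.53 log units lower from compound 2 to compound 3 (beyond the scatter). Compound 3 is therefore estimated at 2.6, with a likely range from 1.6 to 3.6.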

Compound 3, distribution coefficient: 1.48
Beside the measured number, compound 3's estimate is 1.12 log units above it; the measured number lies below the stated range.
By their numbers in this assay, from the lowest: compound 3; then compound 2; then compound 1.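

In this assay, among these compounds, the swap of ((pyridin-4-yl)carbonyl)amino for 3,5-difluorophenyl on an amide-type nitrogen gives a number 3.65 log units lower from compound 2 to compound 3 (beyond the scatter) and offers the first comparison here in which only one place differs. The earlier compounds shown here differ in several places at once, so they could not show how far this position alone can shift the number; this single change produces a large step, well beyond the scatter. No separate measurement indicates which feature of the entering group lies behind the step.

On these data alone, it remains open how much of the step goes with the ring and how much with the carbonyl and extra nitrogen, a question that a benzoylamino group, with its carbon-only ring, could help to separate. As far as these compounds go, whether the same swap would give a step of similar size on the core of compound 1 also remains open.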